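A few compounds are considered here, and "the series" means these few. Any claim that something is new, unique, unknown or untested is made for them only; others in the source may bear on it.

Compound 1 `CCCc1nc(CC)c(C(=O)OCCC[S+]([O-])c2ccccc2)n1Cc1ccc(-c2ccccc2S(=O)(=O)NC(=O)OCCC(C)C)cc1F` is measured in an assay on isolated protein for binding affinity to Type-2 angiotensin II receptor (Homo sapiens) (on this read-out lower numbers stand for stronger inhibition and higher numbers for weaker inhibition), where compound 1 gives 1 nM. Compound 2 `CCCc1nc(CC)c(C(=O)OCc2ccccc2C(=O)c2ccccc2)n1Cc1ccc(-c2ccccc2S(=O)(=O)NC(=O)OCC(C)C)cc1F` gives 1 nM, the same number at the digits shown, and together these two stand lowest of the three numbers. Going by the values given here, compound 3 `CCCc1nc(CC)c(C(=O)NCCCOc2ccccc2)n1Cc1ccc(-c2ccccc2S(=O)(=O)NC(=O)OCCC(C)C)cc1F` gives 9 nM; the step of a 9.0-fold higher number from compound 1 to compound 3 (0.95 log units; beyond the scatter) is the only measured step that touches the chain hanging from the carbonyl of the shared core. Compound 4 `CCCc1nc(CC)c(C(=O)OCCN2C(=O)c3ccccc3C2=O)n1Cc1ccc(-c2ccccc2S(=O)(=O)NC(=O)OCCC(C)C)cc1F` differs from compound 1 by a group of 11 heavy atoms (8 carbon, 1 nitrogen, 2 oxygen; one five-membered non-aromatic ring with 1 hetero atom, one six-membered aromatic ring of carbon only) in place of a group of 9 heavy atoms (7 carbon, 1 oxygen, 1 sulfur; one six-membered aromatic ring of carbon only), on a saturated chain carbon, two bonds along the chain from an oxygen next to a carbonyl group. That measured step is a different change at a different spot, so it is only a loose guide: a swap in that chain cost a modest amount, not more. Compound 4 is therefore expected to give 3 nM, within 1 nM to 15 nM, an expected step of a 3.0-fold higher number from compound 1 to compound 4 (0.48 log units; beyond the scatter), a small rise or none beyond the scatter.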

Compound 4, half-maximal inhibitory concentration: 7 nM
Beside the measured number, compound 4's estimate is 2.3-fold (0.37 log units) below it; the range from low to high includes it.
By their numbers in this assay, from the lowest: compounds 1 and 2 (each within the scatter of the next); then compounds 4 and 3 (each within the scatter of the next).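

On this saturated chain carbon, the group carrying the sulfur can't be exchanged freely: in this assay, the swap to the group with a five-membered non-aromatic ring gives a 7.0-fold higher number from compound 1 to compound 4 (0.85 log units; beyond the scatter). The ester link stays in place here, so the rise comes from a change further along the chain, whereas the earlier step altered the chain at the carbonyl itself. Nothing available here explains this rise. Still open, going by these compounds, is whether a simple amine or a carboxylic acid on this carbon would hold the number of compound 1.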